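The source may report more compounds than this note shows. Statements on the series, on what has been measured and on what is new or still open speak of the compounds shown alone.

Compound 1 `COc1ccc(C(=O)/C=C\Nc2ccc(-c3nc4cc(OC)c(OC)c(OC)c4s3)cc2)cc1[N+](=O)[O-]`: 15900 nM
Compound 2 `COc1ccc2nc(-c3ccc(N/C=C\C(=O)c4cc(OC)c(OC)c(OC)c4Br)c(C)c3)sc2c1`: 23400 nM
Compound 3 `COc1ccc2nc(-c3ccc(N/C=C\C(=O)c4cc(OC)c(OC)c(OC)c4)c(C)c3)sc2c1`: 10000 nM

These three were measured in a functional assay on MIA PaCa-2 cells (Homo sapiens) for antiproliferative activity, read by sulforhodamine B assay, with a stated time of 48 h; a higher number here means a weaker inhibitor, a lower number a stronger inhibitor. Compound 2 has the highest number of the three; compound 1 lies nearest to it, within the scatter, and compound 3 lies furthest, beyond the scatter. Within the data shown here, the one measured single-place step is a 2.3-fold lower number from compound 2 to compound 3 (0.37 log units; beyond the scatter), where hydrogen replaces bromo on an aromatic carbon. Compound 4 `COc1ccc2nc(-c3ccc(N/C=C\C(=O)c4cc(OC)c(OC)c(OC)c4Br)cc3)sc2c1` has not yet been measured. It differs from compound 2 in one place: hydrogen in place of methyl on an aromatic carbon. Among the measured compounds shown here, no measured step bears on this change: the step between compound 2 and compound 3 concerns bromo on a different ring, and compounds 1 and 3 differ in more than one place. With nothing in the data speaking to the loss of the methyl, compound 4 is expected to remain near compound 2. The expected step is a 1.2-fold lower number from compound 2 to compound 4 (0.07 log units; within the scatter), not beyond the scatter. In this assay compound 4 is estimated at 20000 nM, with a range from 8000 nM to 50000 nM.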

Compound 4, half-maximal inhibitory concentration: 14700 nM
The estimate for compound 4 lay 1.4-fold (0.13 log units) above the measured number; measured number inside the range.
By their numbers in this assay, from the lowest: compounds 3, 4, 1 and 2 (each within the scatter of the next, the first and the last beyond it).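

In this assay, the step of a 1.6-fold lower number from compound 2 to compound 4 (0.20 log units; within the scatter) stays within the scatter, so at this aromatic carbon, ortho to a large group, the exchange of methyl for hydrogen on a bromo-bearing compound cannot be told apart from the variation between repeated measurements. Among these compounds, this is the first reading at this position, and the earlier step, a 2.3-fold lower number from compound 2 to compound 3 (0.37 log units; beyond the scatter), which concerns the bromo on a different ring, remains the only single-place step beyond the scatter. Nothing among the data offers an explanation for this result.

Whether methyl and hydrogen also read alike in the absence of the bromo stays open, as compound 3 has no hydrogen counterpart among the compounds shown. Also open, from the compounds shown here alone, is how a hydroxyl, an amine or a longer chain would read on this carbon.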